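The source may report more compounds than this note shows. Statements on the series, on what has been measured and on what is new or still open speak of the compounds shown alone.

Compound 1 `O=C1/C(=C/c2cccnc2)CN(S(=O)(=O)c2ccc([N+](=O)[O-])cc2)C/C1=C\c1ccccc1C(F)(F)F`: 15900 nM
Compound 2 `N#Cc1ccc(S(=O)(=O)N2C/C(=C\c3cccnc3)C(=O)/C(=C/c3ccccc3C(F)(F)F)C2)cc1`: 9650 nM

In a functional assay on SMMC-7721 cells (Homo sapiens) for cytotoxicity, read by MTT assay, with a stated time of 24 h (on this read-out lower numbers stand for stronger inhibition and higher numbers for weaker inhibition), compound 2 gives 9650 nM and stands within the scatter of compound 1. Compound 3 `CC(=O)Nc1ccc(S(=O)(=O)N2C/C(=C\c3cccnc3)C(=O)/C(=C/c3ccccc3C(F)(F)F)C2)cc1` differs from compound 2 by acetamido in place of cyano on an aromatic carbon, with acetamido in place of cyano on an aromatic carbon. Within the data shown here, the only measured step that bears on this is a 1.6-fold lower number from compound 1 to compound 2 (0.22 log units; within the scatter), also an exchange of groups on an aromatic carbon. One such step is thin evidence, but it gives no reason to expect a real shift in this assay. The expected 1.2-fold higher number from compound 2 to compound 3 (0.09 log units; within the scatter) therefore stays within the scatter. The estimated value for compound 3 is 12000 nM, with an expected range from 5000 nM to 30000 nM.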

Compound 3, half-maximal inhibitory concentration: 9830 nM
For compound 3 the middle estimate is 1.2-fold (0.09 log units) above the measured one, within the range that was stated.
By their numbers in this assay, from the lowest: compounds 2, 3 and 1 (each within the scatter of the next).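

In this assay, the step from 4-cyanophenyl to 4-acetamidophenyl gives a 1.0-fold higher number from compound 2 to compound 3 (0.01 log units; within the scatter) and stays within the scatter, and acetamido in place of nitro gives a 1.6-fold lower number from compound 1 to compound 3 (0.21 log units; within the scatter) and also stays within the scatter. This position, para to a large group, therefore takes a group bringing a hydrogen-bond donor without a number that can be told apart from those of the cyano and nitro compounds. Nothing available explains this result.

From the compounds shown here alone, whether an amine, a carboxylic acid or a longer chain at this position would also stay within the scatter remains open. So does whether any group here can move the number at all.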